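Hydroxy in place of methoxy at the tolerance limit

The source may report more compounds than this note shows. Statements on the series, on what has been measured and on what is new or still open speak of the compounds shown alone.

Compound 3 `COc1cc(C)cc(-c2nn(CC#N)cc2-c2ccnc(-c3ccc(N(C)C)cc3)c2)c1` was examined in a functional assay on NCI-H226 cells (Homo sapiens) for inhibition, read by sulforhodamine B assay, with a stated time of 48 h; a higher number here means that more compound is tolerated, a lower number that less compound is tolerated. In this assay compound 3 gives only a limit, > 100000 nM, and no number. Compound 1 `COc1cc(C)cc(-c2nn(CC#N)cc2-c2ccc(-c3cccc(C(C)=O)c3)nc2)c1` likewise gives only a limit, > 100000 nM. For the measured compounds named here, compound 2 `Cc1cc(O)cc(-c2nn(CC#N)cc2-c2ccnc(-c3ccc(Oc4ccccc4)cc3)c2)c1` is the single compound with a measured number, giving 64500 nM in this assay. Compound 3 therefore stands at the edge of what the assay reports, as does most of the set (the limit of > 100000 nM in this assay, at which 2 of the 3 values shown sit). Compound 4 `Cc1cc(O)cc(-c2nn(CC#N)cc2-c2ccnc(-c3ccc(N(C)C)cc3)c2)c1` differs from compound 3 by hydrogen in place of methyl on an oxygen on an aromatic ring: methoxy becomes hydroxy, the 3-methoxy-5-methylphenyl group becoming 3-hydroxy-5-methylphenyl. Going by the values given here, no measured step covers this change, so no direction can be read from the data. The change is expected to give an at least 1.1-fold lower number from compound 3 to compound 4 (0.07 log units; that floor lies within the scatter), a step no larger than the usual scatter. Compound 4 is estimated at 85000 nM, within a range from 35000 nM to 200000 nM.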

Compound 4, concentration lethal to 50% of the cells: > 100000 nM
Compound 4 gave a limit, no number; the forecaster's own chance of this, stated with the estimate: 50%; at least 1.1-fold (0.07 log units) between middle value and limit.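

In this assay compound 4 gives > 100000 nM, which is a limit and not a number. Hydroxy in place of methoxy thus leaves the dimethylamino compound at that limit, and the two limits leave the step between compound 3 and compound 4 unreadable. With hydroxy kept, dimethylamino in place of phenoxy gives an at least 1.5-fold higher number from compound 2 to compound 4 (0.19 log units; that floor lies within the scatter).

Going by these compounds, whether methoxy and hydroxy differ here at all stays open, with most of the set sitting at one limit: the limit of > 100000 nM in this assay, at which 3 of the 4 values shown sit. How an amine or a carboxylic acid in place of the hydroxy would read is also open.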